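Benzyl to butyl: working notes on the series

The source may report more compounds than this note shows. Statements on the series, on what has been measured and on what is new or still open speak of the compounds shown alone.

Among the measured compounds shown here, in a physicochemical assay for lipophilicity, using the shake flask method (on this read-out lower numbers stand for lower lipophilicity and higher numbers for higher lipophilicity), compound 2 (`Nc1ncnc(Oc2ccc(NC(=O)C3(C(=O)Nc4ccc(F)cc4)CC3)cc2F)c1/C=N/OCc1ccccc1`) gives 4.45 as the higher of two numbers so far, and compound 1 (`C=CCO/N=C/c1c(N)ncnc1Oc1ccc(NC(=O)C2(C(=O)Nc3ccc(F)cc3)CC2)cc1F`) gives 3.65 as the lower. Compound 3 (`CCCCO/N=C/c1c(N)ncnc1Oc1ccc(NC(=O)C2(C(=O)Nc3ccc(F)cc3)CC2)cc1F`) is unmeasured and differs from compound 2 by propyl in place of phenyl on a saturated chain carbon bound to an oxygen (propyl in place of phenyl on a saturated chain carbon bound to an oxygen, also readable as benzyl to butyl). For the measured compounds named here, one measured step bears on this change: a number 0.80 log units higher from compound 1 to compound 2 (beyond the scatter) with phenyl in place of vinyl, modest and beyond the scatter. Going by the values given here, no measured compound carries propyl, so this single step is the only guide. A small downward move is expected, much smaller than that step and not beyond the scatter. The expected move is a number 0.15 log units lower from compound 2 to compound 3 (within the scatter) in this assay on this reasoning. For compound 3 the estimated value is 4.3 with an expected range from 3.9 to 4.7 for now.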

Compound 3, partition coefficient: 4.2
Compound 3: the middle estimate sits 0.10 log units above what was measured, and the stated range covers the measured number.
By their numbers in this assay, from the lowest: compound 1; then compounds 3 and 2 (each within the scatter of the next).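

At the saturated chain carbon bound to an oxygen, the phenyl ring of compound 2 can give way to the open propyl chain with the reading staying within the scatter in this assay: the step is a number 0.25 log units lower from compound 2 to compound 3 (within the scatter) and so, among these compounds, an aromatic ring at this place is not required for a number in this range. The vinyl compound now differs from both others, since the step of a number 0.55 log units higher from compound 1 to compound 3 (beyond the scatter) lies beyond the scatter, as does a number 0.80 log units higher from compound 1 to compound 2 (beyond the scatter), so the earlier gap is not specific to phenyl. No measurement at hand accounts for these differences.

The compounds shown leave open whether a longer chain, a branched chain, an amine or a carboxylic acid at this place would read with compound 2 and compound 3 or with compound 1.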